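4-Phenylphenyl for octyl on compound 2

This account rests on a few compounds, and the source may have more. Where it says the series, first, only, none or still open, it means among the compounds named here.

In a functional assay on PK9 cells (Homo sapiens) for inhibition, read by MTT assay, with a stated time of 72 h (a higher number here means a weaker inhibitor, a lower number a stronger inhibitor), compound 1 `C=CCCCCCCCCCOC[C@@H]1CCCN1C(=O)OC(C)(C)C` gives > 100000 nM, which is a limit. Compound 2 `CCCCCCCC/C=C/CCCCCCCCOC[C@@H]1CCCN1C(=O)OC(C)(C)C` gives > 100000 nM, again a limit and not a number, so it stands at the limit of > 100000 nM in this assay, at which 2 of the 3 values shown sit. Compound 3 `CCCCCCCC/C=C/CCCCCCCCOC[C@@H]1CCCN1` gives a measured 9200 nM.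

Compound 4 `CC(C)(C)OC(=O)N1CCC[C@H]1COCCCCCCCC/C=C/c1ccc(-c2ccccc2)cc1` differs from compound 2 by 4-phenylphenyl in place of octyl on a double-bonded chain carbon bound to a double-bonded chain carbon. The chain change a step that the two limits leave unreadable from compound 1 to compound 2 gives no size to build on. The change an at least 10-fold lower number from compound 2 to compound 3 (1.03 log units; beyond the scatter) is large, but it removes the tert-butoxycarbonyl that compound 4 keeps. In this assay the expected change is therefore a number no higher from compound 2 to compound 4 (the limit leaves the size open), with no shift beyond the scatter anticipated. Compound 4 is estimated at 100000 nM, with an expected range of 30000 nM to 300000 nM.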

Compound 4, half-maximal inhibitory concentration: > 100000 nM
Compound 4 ended at the assay's limit; the forecaster's own chance of this, stated with the estimate: 70%; the middle value lies on the limit itself.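

Compound 2 and compound 4 each give only a limit, so no step between them can be read: the limit of > 100000 nM in this assay, at which 3 of the 4 values shown sit.

In this assay, on these data alone, it stays open whether 4-phenylphenyl in place of octyl shifts the number at all, with or without the tert-butoxycarbonyl.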